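The source may hold more compounds than are shown below. What is called first, only, known or untested is meant among the compounds shown, and "the series" means these compounds.

Compound 3 `CC(C)(C)C(Oc1ccc(-n2cc(C(F)(F)F)cn2)cc1)c1ccc(C(=O)NCCC(=O)O)cc1` is the point of departure. In a functional assay on cells for antagonist activity at Glucagon receptor (Homo sapiens), read by cAMP accumulation, in the presence of a further agent that is not named here (a higher number here means a weaker inhibitor, a lower number a stronger inhibitor), compound 3 gives 4300 nM, the highest of the two numbers in hand, yet its nearest neighbour, compound 1 `O=C(O)CCNC(=O)c1ccc(C(Oc2ccc(-n3cc(C(F)(F)F)cn3)cc2)C2CCC2)cc1`, gives in this assay 3000 nM, a gap within the scatter, so the two cannot be told apart. Compound 2 `CCC(Oc1ccc(-n2cc(C(F)(F)F)cn2)cc1)c1ccc(C(=O)NCCC(=O)O)cc1` in this assay gives only a limit, > 22000 nM, and not a number; this value sits at the limit of > 22000 nM in this assay, at which 1 of the 3 values shown sits. Compound 4 `CC(C)CC(Oc1ccc(-n2cc(C(F)(F)F)cn2)cc1)c1ccc(C(=O)NCCC(=O)O)cc1` has not yet been measured. It differs from compound 3 in one place: isobutyl in place of tert-butyl on a saturated chain carbon bound to an aromatic carbon and an oxygen on an aromatic ring. Three measured steps at this position bear on the change. Going from cyclobutyl to tert-butyl gave a 1.4-fold higher number from compound 1 to compound 3 (0.16 log units; within the scatter), going from cyclobutyl to ethyl gave an at least 7.3-fold higher number from compound 1 to compound 2 (0.86 log units; beyond the scatter), and going from ethyl to tert-butyl gave an at least 5.1-fold lower number from compound 2 to compound 3 (0.70 log units; beyond the scatter). The two groups of the same carbon count as isobutyl, cyclobutyl and tert-butyl, thus sit close together, while the shorter ethyl falls clearly behind. Since isobutyl keeps that carbon count, the step expected here is a 1.2-fold higher number from compound 3 to compound 4 (0.07 log units; within the scatter), a number rising little if at all. Compound 4 is therefore estimated to give 5000 nM in this assay, with a range from 2000 nM to 15000 nM.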

Compound 4, antagonist equilibrium constant: 3400 nM
Compound 4: middle estimate off by 1.5-fold (0.17 log units), on the high side; measured number inside the range.
By their numbers in this assay, from the lowest: compounds 1, 4 and 3 (each within the scatter of the next). At a limit, above all of these: compound 2.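

In this assay, the isobutyl group joins cyclobutyl and tert-butyl as a third arrangement of the same four carbons that cannot be told apart from the others, with a 1.3-fold lower number from compound 3 to compound 4 (0.10 log units; within the scatter) and a 1.1-fold higher number from compound 1 to compound 4 (0.05 log units; within the scatter), so among these three compounds the shape of the group makes no readable difference at this position. The step from ethyl, which can also be read as isopropyl in place of methyl on a saturated chain carbon, two bonds along the chain from an aromatic carbon and an oxygen on an aromatic ring, gives an at least 6.4-fold lower number from compound 2 to compound 4 (0.81 log units; beyond the scatter), which shows that the gain over ethyl does not need a branch on the saturated chain carbon bound to the aromatic carbon and the oxygen itself. This comparison rests on a limit and not a number, so its true size stays unknown: the limit of > 22000 nM in this assay, at which 1 of the 4 values shown sits.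

The compounds shown leave open whether isopropyl or n-propyl already matches the four-carbon groups or still falls behind with ethyl. They also leave open whether a longer chain such as n-pentyl, or a larger ring such as cyclohexyl or phenyl, would move the number beyond the scatter of these three compounds.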